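Removing the Methyl: A Furan Hydroxamic Acid Step

The source may hold more compounds than are shown below. What is called first, only, known or untested is meant among the compounds shown, and "the series" means these compounds.

Compound 1 `O=C(/C=C/c1ccc(/C=C/C(=O)c2ccc3ccccc3c2)o1)NO` gives 15100 nM; compound 2 `Cc1ccc(C(=O)/C=C/c2ccc(/C=C/C(=O)NO)o2)cc1` gives 16000 nM; compound 3 `O=C(CCCCCCC(=O)Nc1ccccc1C(=O)NO)Nc1ccccc1` gives 8170 nM.

These three numbers come from a functional assay on PC-3 cells (Homo sapiens) for antiproliferative activity, read by MTT assay, with a stated time of 48 h; a lower number here means a stronger inhibitor, a higher number a weaker inhibitor. Compound 2 has the highest of them, yet compound 1 and compound 3 both lie within the scatter of compound 2, so none of the three can be set apart from the others on this evidence. No pair of these compounds differs in a single place, so no measured step is at hand to guide a prediction.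

Compound 4 `O=C(/C=C/c1ccc(/C=C/C(=O)c2ccccc2)o1)NO` is not yet measured. It differs from compound 2 in one place: hydrogen in place of methyl on an aromatic carbon. On the numbers shown there is nothing to suggest that this small change should move the result beyond the scatter in either direction. Compound 4 is therefore expected to give about 16000 nM in this assay, within a range of 7000 nM to 36000 nM. The step from compound 2 that this estimate means, no change at the digits printed from compound 2 to compound 4 (within the scatter), is expected to be none beyond the scatter.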

Compound 4, half-maximal inhibitory concentration: 13300 nM
Compound 4: the middle estimate sits 1.2-fold (0.08 log units) above what was measured; the range from low to high includes it.
By their numbers in this assay, from the lowest: compounds 3, 4, 1 and 2 (each within the scatter of the next).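

For the compounds shown here, the step is the first single change that can be read in this set. In this assay, going from 4-methylphenyl to phenyl gives a 1.2-fold lower number from compound 2 to compound 4 (0.08 log units; within the scatter), so at this place on the aromatic ring, para to a large group, methyl and hydrogen cannot be told apart. That is all the result shows for this position, which so far has given no sign of mattering to the read-out, though only these two groups have been compared there. No other measurement shown bears on this result.

From the compounds shown here alone, it remains open whether an amine, a carboxylic acid or a longer chain at the same place would move the number beyond the scatter. Going by these compounds, it is also open whether a group of a different kind there would matter more on the core of compound 4 than the methyl did.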